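This account rests on a few compounds, and the source may have more. Where it says the series, first, only, none or still open, it means among the compounds named here.

Among the measured compounds shown here, compound 2 `CCOC(=O)C1=C(Nc2ccccc2)S/C(=C\c2ccc(Br)c(O)c2)C1=O` gives 39.8% in a functional assay on JAR cells (Homo sapiens) for inhibition, read by MTT assay, with a stated time of 72 h, tested at 10 uM (on this read-out lower numbers stand for less inhibition and higher numbers for more inhibition at the one concentration tested (going by the name of the read-out)), the higher of the two numbers so far; compound 1 `CCOC(=O)C1=C(Nc2ccccc2)S/C(=C\c2ccccc2)C1=O` gives 20.3%. For the measured compounds named here, the only measured step, a number 19.5 percentage points higher from compound 1 to compound 2 (beyond the scatter), shows that changing the group on the double-bonded chain carbon can shift inhibition modestly. Compound 3 `CCOC(=O)C1=C(Nc2ccccc2)S/C(=C\c2ccc(C(=O)O)cc2)C1=O` differs from compound 2 by 4-carboxyphenyl in place of 4-bromo-3-hydroxyphenyl on a double-bonded chain carbon bound to a double-bonded ring carbon. Going by the values given here, no measured step involves the carboxyphenyl group, so the direction is uncertain, and a step of about the size already seen, in either direction, seems possible. Compound 3 is therefore expected to give roughly 30%, within 10% to 55%, meaning an expected step of a number 9.8 percentage points lower from compound 2 to compound 3 (within the scatter).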

Compound 3, a percentage reported as inhibition, at one concentration (the size of the read-out at that concentration, not a potency): 16.8%
Beside the measured number, compound 3's estimate is 13.2 percentage points above it, within the range that was stated.
By their numbers in this assay, from the lowest: compounds 3 and 1 (each within the scatter of the next); then compound 2.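

In this assay there is a number 23 percentage points lower from compound 2 to compound 3 (beyond the scatter) so 4-carboxyphenyl does not hold the higher number seen with 4-bromo-3-hydroxyphenyl at this position. Set against the plain phenyl there is a number 3.5 percentage points lower from compound 1 to compound 3 (within the scatter) so adding carboxy leaves inhibition indistinguishable from that of compound 1, and of these three groups only 4-bromo-3-hydroxyphenyl stands apart. Nothing measured here explains the difference. On these data alone, whether a phenyl carrying only the bromine or only the hydroxy would match compound 2 stays open. So does what an amine or a methyl ester would give in place of the carboxy group.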